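The source may report more compounds than this note shows. Statements on the series, on what has been measured and on what is new or still open speak of the compounds shown alone.

Measured in a functional assay on KB cells (Homo sapiens) for inhibition, read by sulforhodamine B assay; on this read-out lower numbers stand for stronger inhibition of growth and higher numbers for weaker inhibition of growth:
- compound 1 `c1ccc(-c2ccc(-c3ccc(-c4nc5ccccc5[nH]4)cc3)cc2)cc1` gives 39700 nM
- compound 2 `COc1ccc(-c2ccc(-c3ccc(-c4nc5cc(C)ccc5[nH]4)cc3)cc2)cc1OC` gives 2190 nM
- compound 3 `Fc1ccc(-c2ccc(-c3ccc(-c4nc5ccccc5[nH]4)cc3)cc2)cc1` gives 41300 nM

Compound 2 (2190 nM) lies well below compound 3 (41300 nM), and compound 3 matches compound 1 within the scatter. Compound 4 (`FC(F)(F)c1ccc(-c2ccc(-c3ccc(-c4nc5ccccc5[nH]4)cc3)cc2)cc1`) carries trifluoromethyl in place of fluoro on an aromatic carbon, para to a large group (trifluoromethyl in place of fluoro on an aromatic carbon). Going by the values given here, the one measured step bearing on this is fluoro in place of hydrogen on an aromatic carbon (a 1.0-fold higher number from compound 1 to compound 3 (0.02 log units; within the scatter)), which stayed within the scatter. Among the compounds with values here, no measured step involves trifluoromethyl, and compound 2 differs from compound 3 in more than one place. In this assay no change beyond the scatter is therefore expected, and the estimated step is small (a 1.2-fold lower number from compound 3 to compound 4 (0.07 log units; within the scatter)). Compound 4 is expected near 35000 nM (estimated range 12000 nM to 80000 nM).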

Compound 4, concentration for 50% growth inhibition: 47200 nM
The estimate for compound 4 lay 1.3-fold (0.13 log units) below the measured number; low and high end bracket the measured number.
By their numbers in this assay, from the lowest: compound 2; then compounds 1, 3 and 4 (each within the scatter of the next).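

Trifluoromethyl on an aromatic carbon para to a large group leaves the number in this assay within the scatter, both against fluoro (a 1.1-fold higher number from compound 3 to compound 4 (0.06 log units; within the scatter)) and against hydrogen (a 1.2-fold higher number from compound 1 to compound 4 (0.08 log units; within the scatter)). The position thus tolerates four heavy atoms in place of one without a change beyond the scatter, which the step to fluoro alone could not show. Nothing at hand gives a reason for this.

From the compounds shown here alone, whether an amine or a carboxylic acid at this position would move the number stays open. So does the effect of any single change elsewhere on the shared core.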